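Methoxy removal from the core in a flat series

The compounds below may be only part of what the source reports. "The series", "measured", "known", "first", "only" and "open" are said of these compounds alone.

- compound 1 `COc1cc(C(=O)/C=C\Nc2ccc(-c3nc4cc(OC)c(OC)c(OC)c4s3)cc2)c(Br)c(OC)c1OC` gives 15600 nM
- compound 2 `COc1ccc2nc(-c3ccc(N/C=C\C(=O)c4cc(OC)c(OC)c(OC)c4)cc3)sc2c1` gives 19600 nM
- compound 3 `COc1ccc2nc(-c3ccc(N/C=C\C(=O)c4ccc(OC)c([N+](=O)[O-])c4)cc3)sc2c1` gives 17600 nM

All three values come from a functional assay on MDA-MB-231 cells (Homo sapiens) for antiproliferative activity, read by sulforhodamine B assay, with a stated time of 48 h; a higher number here means a weaker inhibitor, a lower number a stronger inhibitor. Compound 1 stands with the other two: its nearest neighbour and its furthest neighbour both lie within the usual scatter, so the numbers do not separate these compounds. For the measured compounds named here, no measured pair differs in one place only, which leaves the contribution of any single group unmeasured.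

Compound 4 `COc1cc(OC)c2sc(-c3ccc(N/C=C\C(=O)c4cc(OC)c(OC)c(OC)c4Br)cc3)nc2c1` keeps the structure of compound 1 except for hydrogen in place of methoxy on an aromatic carbon of the core (hydrogen in place of methoxy on an aromatic carbon). The closest indirect evidence is that compound 2 at 19600 nM and compound 3 at 17600 nM carry fewer methoxy groups on the core than compound 1 at 15600 nM, and all three remain within the scatter. These two compounds also differ from compound 1 elsewhere, so this comparison is only a weak guide. In this assay no step beyond the scatter is expected, and the direction is left open. The estimated change is a 1.1-fold higher number from compound 1 to compound 4 (0.04 log units; within the scatter). For compound 4 the expected value is 17000 nM, with an estimated range from 8000 nM to 32000 nM.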

Compound 4, half-maximal inhibitory concentration: 16100 nM
Compound 4: middle estimate off by 1.1-fold (0.02 log units), on the high side; measured number inside the range.
By their numbers in this assay, from the lowest: compounds 1, 4, 3 and 2 (each within the scatter of the next).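

In this assay the series now has its first comparison that differs in one place only: hydrogen in place of methoxy on an aromatic carbon of the core gives a 1.0-fold higher number from compound 1 to compound 4 (0.01 log units; within the scatter), a step within the scatter. The earlier compounds shown here could not show this, since each of them also differs from compound 1 elsewhere, so the change could not be read from them alone. On the background of compound 1, the methoxy group at this carbon, ortho to two methoxy groups, meta to a fused ring and para to a fused ring, can therefore give way to hydrogen with no separation in this read-out, though nothing in hand bears on the reason for this result.

From the compounds shown here alone, whether a hydroxyl group or an amine at this same carbon would also stay within the scatter remains open, and a single step cannot say whether any group here can move the number at all. Also open, going by these compounds, is whether the same change would read alike on the other methoxy positions of the core, or on a background without the bromine of compound 1.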